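Fluoro for Methyl on the Pendant Ring: Cytotoxicity Outlook

A few compounds are considered here, and "the series" means these few. Any claim that something is new, unique, unknown or untested is made for them only; others in the source may bear on it.

Compound 1 `O=c1[nH]cc(S(=O)(=O)Nc2ccccc2-c2cn(-c3ccccc3F)nn2)c(=O)[nH]1`: in an ADME assay on GES1 cells (Homo sapiens) for cytotoxicity, read by MTT assay, with a stated time of 24 h (a lower number here means that less compound is tolerated, a higher number that more compound is tolerated), compound 1 gives > 100000 nM, which is a limit of the assay and not a number.
Compound 2 `O=c1[nH]cc(S(=O)(=O)Nc2cccc(-c3cn(-c4cccc(F)c4)nn3)c2)c(=O)[nH]1`: compound 2 gives "not toxic" (no number reported) in this assay.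
Compound 3 `Cc1ccccc1-n1cc(-c2ccc(NS(=O)(=O)c3c[nH]c(=O)[nH]c3=O)cc2)nn1`: compound 3 gives "not toxic" (no number reported) in this assay.

Compound 3 thus stands without a single number in this assay; of the other two entries, one is a limit and one carries no number either. Compound 4 `O=c1[nH]cc(S(=O)(=O)Nc2ccc(-c3cn(-c4ccccc4F)nn3)cc2)c(=O)[nH]1` differs from compound 3 by fluoro in place of methyl on an aromatic carbon. For the measured compounds named here, no step between measured compounds has been recorded, so the size of the change cannot be read from data; the expectation is no shift beyond the scatter in this assay. Compound 4 is therefore estimated at 150000 nM, in the range 50000 nM to 500000 nM, most likely again reported only as a limit.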

Compound 4, half-maximal cytotoxic concentration: > 100000 nM
Compound 4: only a limit was reported; the forecaster's own chance of this, stated with the estimate: 85%; the middle value does not contradict the limit.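

No step can be read from compound 3 to compound 4 in this assay, because compound 3 carries no number and compound 4 sits at a limit of the assay, not a number: the limit of > 100000 nM in this assay, at which 2 of the 4 values shown sit. The compounds shown leave open how much of any of them is tolerated past that limit, and whether methyl and fluoro differ there.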